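Replacing nitro with ethoxycarbonyl in compound 1

The source may hold more compounds than are shown below. What is called first, only, known or untested is meant among the compounds shown, and "the series" means these compounds.

Compound 1 (`O=[N+]([O-])c1ccc(NC(=S)Nc2cccc(C(F)(F)F)c2)cc1`) is the starting point of this account. In an ADME assay on MT4 cells (Homo sapiens) for cytotoxicity (on this read-out higher numbers stand for lower toxicity in this test and lower numbers for higher toxicity in this test), compound 1 gives 9200 nM. Going by the values given here, compound 3 (`FC(F)(F)c1cccc(NC(=S)Nc2cccc(Br)c2)c1`) gives 9200 nM, level with compound 1 within the scatter, and together they hold the lowest number of the three compounds measured so far. Compound 2 (`CCCCc1ccc(NC(=S)Nc2cccc(C(F)(F)F)c2)c(C)c1`) stands apart at 43000 nM, a higher number that lies beyond the scatter of the other two.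

Compound 4 (`CCOC(=O)c1ccc(NC(=S)Nc2cccc(C(F)(F)F)c2)cc1`) has not yet been measured. It keeps the core of compound 1 but carries ethoxycarbonyl in place of nitro on an aromatic carbon, para to a large group: ethoxycarbonyl in place of nitro on an aromatic carbon. Among the compounds with values here, no measured pair of compounds differs in only one place, so the data offer no direct guide to this exchange. Compound 1 at 9200 nM and compound 2 at 43000 nM mark the span seen so far, and the expectation for this assay is that compound 4 will fall within it, towards the lower end. The expected size of the change is a 1.5-fold higher number from compound 1 to compound 4 (0.18 log units; within the scatter), a small upward move that would stay within the scatter. For compound 4 the estimated value is 14000 nM, with an expected range from 5000 nM to 40000 nM.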

Compound 4, half-maximal cytotoxic concentration: 23000 nM
Beside the measured number, compound 4's estimate is 1.6-fold (0.22 log units) below it, within the range that was stated.
By their numbers in this assay, from the lowest: compounds 1 and 3 (each within the scatter of the next); then compounds 4 and 2 (each within the scatter of the next).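

In this assay, going by these compounds alone, ethoxycarbonyl in place of nitro on an aromatic carbon, para to a large group, gives a 2.5-fold higher number from compound 1 to compound 4 (0.40 log units; beyond the scatter), the first single exchange that can be read. It is a modest step, but it lies beyond the scatter and points towards lower toxicity in this test, so this position is not indifferent to the group it carries. The step appears although the hydrogen-bond donor and acceptor counts of the two groups are the same and both have a double bond outside aromatic rings; what changes in those counts is that the entering group has more heavy atoms and carbon where nitro has nitrogen, and nothing measured here says why the number rises.

The compounds shown leave open whether the rise belongs to the ester as such or to the larger size of the group, a question that a carboxylic acid, an amine or a longer alkyl ester at the same carbon would address. They also leave open whether the same exchange would give a step of similar size on a compound with a different second ring, such as one carrying bromine.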